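This account rests on a few compounds, and the source may have more. Where it says the series, first, only, none or still open, it means among the compounds named here.

Working notes on the series in a functional assay on DU-145 cells (Homo sapiens) for cytotoxicity, read by MTT assay; a lower number here means a stronger inhibitor, a higher number a weaker inhibitor.

Compound 1 `CC(O)(CSc1ccc(Br)cc1)c1nc(-c2ccccc2)no1` gives > 100000 nM, which is a limit of the assay and not a number (the limit of > 100000 nM in this assay, at which 1 of the 3 values shown sits). Compound 2 `CC(O)(CSc1ccc(Br)cc1)c1nc(-c2ccc(Cl)cc2)no1` gives 6500 nM. The change from compound 1 to compound 2 is chloro in place of hydrogen on an aromatic carbon; it produced an at least 15-fold lower number from compound 1 to compound 2 (1.18 log units; beyond the scatter).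

Compound 3 `CC(O)(CSc1ccccc1)c1nc(-c2ccc([N+](=O)[O-])c(C(F)(F)F)c2)no1` gives 3000 nM, the lowest number among the measured compounds, with compound 2 nearest to it. The difference between the core of compound 3 and the core of compound 1 is not broken down here.

Compound 4 `CC(O)(CSc1ccc(Cl)cc1)c1nc(-c2ccc([N+](=O)[O-])c(C(F)(F)F)c2)no1` has not been measured. It differs from compound 3 by chloro in place of hydrogen on an aromatic carbon, the same change that was made from compound 1 to compound 2, though read one bond further out it concerns the phenylsulfanyl group, which becomes (4-chlorophenyl)sulfanyl. The earlier step rests on a limit in compound 1 and sets only a floor for its size; with one example, and that on a different ring, the step here is expected to be smaller, a 2.5-fold lower number from compound 3 to compound 4 (0.40 log units; beyond the scatter). Compound 4 is therefore estimated at 1200 nM, between 300 nM and 4500 nM.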

Compound 4, half-maximal inhibitory concentration: 1300 nM
Beside the measured number, compound 4's estimate is 1.1-fold (0.03 log units) below it; the measured number falls inside the stated range.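

In this assay, chloro in place of hydrogen on an aromatic carbon again gives a lower number, a 2.3-fold lower number from compound 3 to compound 4 (0.36 log units; beyond the scatter), so the direction of the change carries over to the core of compound 3, where phenylsulfanyl becomes (4-chlorophenyl)sulfanyl. The size of the step does not carry over, as the two steps lie further apart than the scatter of two such steps allows: the same change on two cores in this assay, an at least 15-fold lower number (1.18 log units; beyond the scatter) from compound 1 to compound 2 and a 2.3-fold lower number (0.36 log units; beyond the scatter) from compound 3 to compound 4, at least 6.6-fold (0.82 log units) apart, beyond the scatter of two such steps. The earlier step rests on a value that is a limit of the assay and not a number, and two examples on different rings and different cores do not show whether the gap follows the core or the ring that carries the chloro: the limit of > 100000 nM in this assay, at which 1 of the 4 values shown sits.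

Still open, as far as these compounds go, is whether a methoxy group or an amine in place of the chloro on the phenyl ring of the (4-chlorophenyl)sulfanyl group would give a step of similar direction. Also open, from the compounds shown here alone, is how a longer chain in place of the (phenylsulfanyl)methyl group would read in this assay.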